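The source may report more compounds than this note shows. Statements on the series, on what has been measured and on what is new or still open speak of the compounds shown alone.

Measured compounds and their values:

Compound 1, `COc1ccc(-c2nc3ccccc3s2)cc1NC(=O)c1cnccc1Cl`: 340 nM
Compound 2, `O=C(Nc1cc(-c2nc3ccccc3s2)ccc1F)c1cnccc1Cl`: 180 nM
Compound 3, `COc1ccc(-c2nc3ccccc3o2)cc1NC(=O)c1cnccc1Cl`: 1680 nM

All three were measured in a physicochemical assay for solubility, in phosphate buffer, measured as kinetic solubility, with a stated time of 18 h, at pH 7.4; on this read-out lower numbers stand for lower solubility and higher numbers for higher solubility. Compound 1 gives 340 nM in this assay, compound 2 gives 180 nM, and compound 3 gives 1680 nM, the highest of the three.

Compound 2 comes from compound 1 by one change, (fluoro in place of methoxy on an aromatic carbon), and the measured step is a 1.9-fold lower number from compound 1 to compound 2 (0.28 log units; within the scatter). Compound 3 comes from compound 1 by a change in the core, (1,3-benzoxazol-2-yl in place of 1,3-benzothiazol-2-yl on an aromatic carbon), and the step is a 4.9-fold higher number from compound 1 to compound 3 (0.69 log units; beyond the scatter).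

Compound 4, `O=C(Nc1cc(-c2nc3ccccc3o2)ccc1F)c1cnccc1Cl`, has not yet been measured in this assay. It comes from compound 3 by the change (fluoro in place of methoxy on an aromatic carbon). Within the data shown here, this is the same kind of change as the one from compound 1 to compound 2, not the same change: in compound 4 the place is para to a 1,3-benzoxazol-2-yl group, whereas in compound 2 it is para to a 1,3-benzothiazol-2-yl group. Among the measured compounds shown here, the core of compound 3 and compound 4 is the one whose own step, from compound 1 to compound 3, was modest and beyond the scatter.

From compound 3 to compound 4 the step is expected to be a 1.9-fold lower number from compound 3 to compound 4 (0.27 log units; within the scatter). This expectation rests on the measured step of a 1.9-fold lower number from compound 1 to compound 2 (0.28 log units; within the scatter), which is the same kind of change and stayed within the scatter. Compound 4 is therefore estimated to give 900 nM in this assay, with a likely range from 400 nM to 2000 nM.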

Compound 4, solubility: 130 nM
For compound 4 the middle estimate is 6.9-fold (0.84 log units) above the measured one; measured number below the stated range.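

In this assay, the change from methoxy to fluoro did not carry over at its measured size: on the core of compound 1 it gave a 1.9-fold lower number from compound 1 to compound 2 (0.28 log units; within the scatter) and on the core of compound 3 it gave a 13-fold lower number from compound 3 to compound 4 (1.11 log units; beyond the scatter). A step measured on one core was therefore a poor guide to the size of the same change on the other core, and with fluoro in place compound 2 gives 180 nM and compound 4 gives 130 nM in the same read-out. This is one pair of compounds on each of two cores, not a general rule for the series, and nothing at hand explains why the two steps differ in size.

The compounds shown carry only methoxy or fluoro at this place, so it remains open how an amine, a carboxylic acid or a longer chain such as ethoxy would behave there on either core. On these data alone, it also remains open whether a large step like the one on the core of compound 3 would appear again with such groups, or whether it belongs to this one pair alone.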